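The source may hold more compounds than are shown below. What is called first, only, known or untested is meant among the compounds shown, and "the series" means these compounds.

Compound 3 `O=C(Nc1ccc(F)c(-c2nc3ncc(-c4ccc(F)cc4F)cc3[nH]2)c1)N1CCCC1` gives 9500 nM in an ADME assay on the whole organism (Mus musculus, strain Swiss Webster) for pharmacokinetics, read by LC-MS, at a dose of 50 mg/kg by the oral route (on this read-out lower numbers stand for lower exposure and higher numbers for higher exposure at the dose given), the highest number of the three measured, although its step to compound 1 lies within the scatter. Compound 1 `O=C(Nc1ccc(F)c(-c2nc3ncc(-c4cccc(F)c4)cc3[nH]2)c1)N1CCCC1` gives 7000 nM in this assay; the step of a 1.4-fold higher number from compound 1 to compound 3 (0.13 log units; within the scatter) does not separate the two. Compound 2 `O=C(Nc1ccc(F)c(-c2nc3ncc(-c4cncc(F)c4)cc3[nH]2)c1)N1CCCC1` gives 1070 nM; the step of an 8.9-fold higher number from compound 2 to compound 3 (0.95 log units; beyond the scatter) is beyond the scatter, and the step of a 6.5-fold lower number from compound 1 to compound 2 (0.82 log units; beyond the scatter) points the same way. Compound 4 `O=C(Nc1ccc(F)c(-c2nc3ncc(-c4ccc(O)cc4)cc3[nH]2)c1)N1CCCC1` is not yet measured. It differs from compound 3 only at the aryl group: 4-hydroxyphenyl in place of 2,4-difluorophenyl on an aromatic carbon. For the measured compounds named here, no measured step introduces a 4-hydroxyphenyl, and none of the measured compounds carries a hydroxyl, so the bearing of the measured steps is indirect: they show that exchanging the aryl group at this position moves the number by amounts ranging from within the scatter to modest. On that basis a modest fall is expected, a 3.8-fold lower number from compound 3 to compound 4 (0.58 log units; beyond the scatter), with wide uncertainty. Compound 4 is estimated at 2500 nM, with a range from 700 nM to 8000 nM.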

Compound 4, maximal plasma concentration: 130 nM
The estimate for compound 4 lay 19-fold (1.28 log units) above the measured number; measured number below the stated range.
By their numbers in this assay, from the lowest: compound 4; then compound 2; then compounds 1 and 3 (each within the scatter of the next).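

For the compounds shown here, the aryl group at this position can move the number in this assay much further than the earlier exchanges showed: the step is large for a 73-fold lower number from compound 3 to compound 4 (1.86 log units; beyond the scatter) and for a 54-fold lower number from compound 1 to compound 4 (1.73 log units; beyond the scatter), where the earlier steps were modest at most. The fall also holds against the compound that was previously lowest, with an 8.2-fold lower number from compound 2 to compound 4 (0.92 log units; beyond the scatter), so a 4-hydroxyphenyl at this carbon gives the lowest number of the four. Going by these compounds alone, compound 4 is also the only one here whose aryl group carries a hydrogen-bond donor, and it has no fluorine on that group.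

Nothing at hand accounts for this fall. As far as these compounds go, whether it follows the hydroxyl itself or the loss of fluorine stays open, and a 4-methoxyphenyl, a 4-fluorophenyl or a 4-aminophenyl group at this carbon would separate those readings.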